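A few compounds are considered here, and "the series" means these few. Any claim that something is new, unique, unknown or untested is made for them only; others in the source may bear on it.

Compounds measured:
compound 1, `CCCOC(=O)CCC(=O)N1CCN(CCCOc2cc3c(Nc4ccc(F)c(Cl)c4)ncnc3cc2OC)CC1`: 80.9%
compound 2, `CCCCCCCCCCOC(=O)CCC(=O)N1CCN(CCCOc2cc3c(Nc4ccc(F)c(Cl)c4)ncnc3cc2OC)CC1`: 15.5%

Within the data shown here, compound 2 gives the lowest of the two numbers in a functional assay on A549 cells (Homo sapiens) for cytotoxicity, read by MTT assay, with a stated time of 24 h, tested at 40 uM; on this read-out higher numbers stand for a weaker effect at the one concentration tested and lower numbers for a stronger effect; its only neighbour is compound 1, and the change a number 65.4 percentage points lower from compound 1 to compound 2 (beyond the scatter) was large and beyond the scatter.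

Compound 3, `CCCCCCCCCCCCCCOC(=O)CCC(=O)N1CCN(CCCOc2cc3c(Nc4ccc(F)c(Cl)c4)ncnc3cc2OC)CC1`, differs from compound 2 in one place: butyl in place of hydrogen on a saturated chain carbon, ten or more bonds along the chain from an oxygen next to a carbonyl group. Among the measured compounds shown here, the only measured step that bears on this change is the one from compound 1 to compound 2, where heptyl in place of hydrogen on the chain lowered the read-out sharply. Compound 3 extends that same chain further by butyl. Since compound 2 already sits low on this read-out, little room remains for a further fall, so a small step downward or none beyond the scatter is expected, a number 5.5 percentage points lower from compound 2 to compound 3 (within the scatter). On that basis compound 3 is estimated at 10%, within the range 2% to 25%.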

Compound 3, a percentage reported as activity, at one concentration (the size of the read-out at that concentration, not a potency): 88.6%
For compound 3 the middle estimate is 78.6 percentage points below the measured one; measured number outside the range, above it.
By their numbers in this assay, from the lowest: compound 2; then compounds 1 and 3 (each within the scatter of the next).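

In this assay, adding butyl on a saturated chain carbon reverses the direction seen with heptyl, giving a number 73.1 percentage points higher from compound 2 to compound 3 (beyond the scatter). Undecyl in place of hydrogen, three bonds along the chain from an oxygen next to a carbonyl group, gives a number 7.7 percentage points higher from compound 1 to compound 3 (within the scatter), so lengthening this chain does not steadily lower the read-out, and compound 3 goes against any such trend. No available evidence accounts for this reversal.

With only three chain lengths shown, the compounds leave open where between compound 2 and compound 3 the read-out turns back and how sharply it does so. They also leave open how a longer chain, or a carboxylic acid or an amine at the chain end, would read here.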